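Removing a Methyl Group: What to Expect for Compound 4

A few compounds are considered here, and "the series" means these few. Any claim that something is new, unique, unknown or untested is made for them only; others in the source may bear on it.

Compound 3 `Cc1cc(-c2ccccc2)n(/C(N)=N/S(=O)(=O)c2cc(C)c(Cl)cc2SCc2ccc(C(F)(F)F)cc2)n1` gives 7000 nM in a functional assay on HCT-116 cells (Homo sapiens) for cytotoxicity, read by MTT assay, with a stated time of 72 h (on this read-out higher numbers stand for weaker inhibition and lower numbers for stronger inhibition), and compound 1 `Cc1cc(S(=O)(=O)/N=C(\N)n2nccc2-c2ccccc2)c(SCc2cccc(Cl)c2)cc1Cl` gives 7000 nM, so the two stand level at the digits shown and together form the lowest pair of the three numbers measured. Compound 2 `Cc1cc(S(=O)(=O)/N=C(\N)n2nccc2-c2ccccc2)c(SCc2ccccc2)cc1Cl` gives 12000 nM, which lies within the scatter of both. For the measured compounds named here, the only step measured between two compounds that differ in one place is a 1.7-fold higher number from compound 1 to compound 2 (0.23 log units; within the scatter), a change of hydrogen in place of chloro on an aromatic carbon in another part of the molecule; it stays within the scatter.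

Compound 4 `Cc1cc(S(=O)(=O)/N=C(\N)n2nccc2-c2ccccc2)c(SCc2ccc(C(F)(F)F)cc2)cc1Cl` differs from compound 3 by hydrogen in place of methyl on an aromatic carbon. Going by the values given here, no measured step touches this part of the shared core, so the change has no direct precedent here. Among the compounds with values here, the one measured step, a 1.7-fold higher number from compound 1 to compound 2 (0.23 log units; within the scatter), shows only that a small change elsewhere left the number within the scatter. Compound 4 is therefore expected to show a 1.1-fold higher number from compound 3 to compound 4 (0.06 log units; within the scatter), no step beyond the scatter. The estimate for compound 4 in this assay is 8000 nM, with a range from 3500 nM to 18000 nM.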

Compound 4, half-maximal inhibitory concentration: 14000 nM
Beside the measured number, compound 4's estimate is 1.8-fold (0.24 log units) below it, and the stated range covers the measured number.
By their numbers in this assay, from the lowest: compounds 1, 3, 2 and 4 (each within the scatter of the next).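

In this assay, for the compounds shown here, the change from 3-methyl-5-phenyl-1H-pyrazol-1-yl to 5-phenyl-1H-pyrazol-1-yl gives the first measured step at this ring carbon: a 2.0-fold higher number from compound 3 to compound 4 (0.30 log units; within the scatter) and so the loss of methyl here does not go beyond the scatter. Compound 4 also joins compounds 1 and 2 on the core without this methyl, where trifluoromethyl in place of hydrogen gives a 1.2-fold higher number from compound 2 to compound 4 (0.07 log units; within the scatter) and 4-(trifluoromethyl)phenyl in place of 3-chlorophenyl gives a 2.0-fold higher number from compound 1 to compound 4 (0.30 log units; within the scatter) and neither step goes beyond the scatter. No accompanying measurement offers an explanation for these numbers.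

Going by these compounds, what an ethyl group, an amine or a carboxylic acid at this ring carbon would give remains open. On these data alone, the methyl step also rests on this single pair, so whether it holds alongside 3-chlorophenyl or an unsubstituted phenyl is unknown.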